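A few compounds are considered here, and "the series" means these few. Any claim that something is new, unique, unknown or untested is made for them only; others in the source may bear on it.

Measured compounds in this series:

Compound 1 `[O-]/[N+](=C\c1cn(CCC(F)(F)C(F)(F)C(F)(F)C(F)(F)C(F)(F)C(F)(F)F)nn1)Cc1ccccc1`. In a functional assay on A549 cells (Homo sapiens) for inhibition, read by MTT assay, with a stated time of 24 h (a lower number here means a stronger inhibitor, a higher number a weaker inhibitor), compound 1 reaches only a limit of the assay, > 100000 nM.
Compound 2 `[O-]/[N+](=C\c1cn(CCC(F)(F)C(F)(F)C(F)(F)C(F)(F)C(F)(F)C(F)(F)C(F)(F)C(F)(F)F)nn1)Cc1ccccc1`. In this assay compound 2 gives 8800 nM.
Compound 3 `CCCCCCCCCCn1cc(/C=[N+](\[O-])C(C)(C)C)nn1`. In this assay compound 3 gives 24800 nM.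

Compound 2 stands at the lowest of the two numbers in this assay; the nearest, compound 3, sits higher by a margin beyond the scatter, and the remaining entry is a limit (the limit of > 100000 nM in this assay, at which 1 of the 3 values shown sits). Among the compounds with values here, the single step measured between compounds differing in one place is an at least 11-fold lower number from compound 1 to compound 2 (1.05 log units; beyond the scatter), a large one, and it concerns the fluorinated chain, not the group on the double-bonded nitrogen.

Compound 4 `CC(C)(C)/[N+]([O-])=C/c1cn(CCC(F)(F)C(F)(F)C(F)(F)C(F)(F)C(F)(F)C(F)(F)C(F)(F)C(F)(F)F)nn1` differs from compound 2 by tert-butyl in place of benzyl on a double-bonded nitrogen. Within the data shown here, no measured step bears on this change. Among the measured compounds shown here, compound 2 and compound 3 differ in more than one place, so their two values show only that the tert-butyl compound with a decyl chain gives the higher number. The step in this assay is therefore expected to be small: a 1.7-fold higher number from compound 2 to compound 4 (0.23 log units; within the scatter) is the estimate, not beyond the scatter. For compound 4 the expected value is 15000 nM, with a range from 5000 nM to 50000 nM.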

Compound 4, half-maximal inhibitory concentration: 30500 nM
The estimate for compound 4 lay 2.0-fold (0.31 log units) below the measured number; the range from low to high includes it.
By their numbers in this assay, from the lowest: compound 2; then compounds 3 and 4 (each within the scatter of the next). At a limit, above all of these: compound 1.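

In this assay the group on the double-bonded nitrogen now has a measured step of its own: a 3.5-fold higher number from compound 2 to compound 4 (0.54 log units; beyond the scatter) on the same fluorinated chain, with benzyl giving the lower number. The earlier values could not show this, since compound 2 and compound 3 differ in more than one place. With tert-butyl on that nitrogen, decyl compound 3 gives 24800 nM and fluorinated compound 4 gives 30500 nM in this assay and these lie within the scatter of each other, so the two chains are not told apart on this pair.

Nothing shown accounts for the step from benzyl to tert-butyl. Open, on these data alone, are whether the step holds on the shorter fluorinated chain of compound 1 and how a cyclohexyl group or a methoxy-bearing benzyl group would read at this position.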